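Amide nitrogen substituents: aryl against benzyl

This account rests on a few compounds, and the source may have more. Where it says the series, first, only, none or still open, it means among the compounds named here.

Measured compounds in a functional assay (QGY7701 cells, Homo sapiens) for inhibition, read by MTT assay, with a stated time of 48 h; on this read-out lower numbers stand for stronger inhibition and higher numbers for weaker inhibition:
compound 1, `COc1ccc2c(=O)c(/C=C/C(=O)Nc3cccc(Cl)c3)coc2c1`, gives > 100000 nM, a limit of the assay.
compound 2, `COc1ccc2c(=O)c(/C=C/C(=O)Nc3cc(C)ccc3C)coc2c1`, gives > 100000 nM, again a limit.
compound 3, `COc1ccc2c(=O)c(/C=C/C(=O)NCc3ccccc3F)coc2c1`, gives 34000 nM.

Within the data shown here, compound 3 thus holds the only actual number in this assay; the other two values are limits. Both measured steps lead to it: from compound 1 to compound 3 an at least 2.9-fold lower number from compound 1 to compound 3 (0.46 log units; beyond the scatter), and from compound 2 to compound 3 an at least 2.9-fold lower number from compound 2 to compound 3 (0.46 log units; beyond the scatter). In both, a 2-fluorobenzyl on the amide-type nitrogen replaces an aryl set directly on that nitrogen.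

Compound 4, `COc1ccc2c(=O)c(/C=C/C(=O)Nc3ccccc3C)coc2c1`, reverses that direction: 2-methylphenyl in place of 2-fluorobenzyl on an amide-type nitrogen. It therefore resembles compound 1 and compound 2 in bearing an aryl directly on the nitrogen, and both of those sit at the limit of > 100000 nM in this assay, at which 2 of the 3 values shown sit. Compound 4 is accordingly expected to show a step of a 2.9-fold higher number from compound 3 to compound 4 (0.47 log units; beyond the scatter), an increase, with a fair chance that this assay again reports only a limit. The estimate for compound 4 is 100000 nM, in the range 34000 nM to 300000 nM.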

Compound 4, half-maximal inhibitory concentration: 22500 nM
Beside the measured number, compound 4's estimate is 4.4-fold (0.65 log units) above it; measured number outside the range, below it.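

An aryl set directly on the amide-type nitrogen does not by itself push the value to the limit in this assay: 2-methylphenyl and 2-fluorobenzyl cannot be told apart, with a 1.5-fold lower number from compound 3 to compound 4 (0.18 log units; within the scatter). The substituents on the aryl ring therefore matter, with an at least 4.4-fold lower number from compound 2 to compound 4 (0.64 log units; beyond the scatter) when one methyl gives way to hydrogen, and an at least 4.4-fold lower number from compound 1 to compound 4 (0.64 log units; beyond the scatter) when 2-methylphenyl replaces 3-chlorophenyl. Compound 1 and compound 2 remain limits, and the step between them cannot be read: the limit of > 100000 nM in this assay, at which 2 of the 4 values shown sit.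

Whether the single methyl contributes at all stays open, since an unsubstituted phenyl on the same nitrogen is not among the compounds shown. A 2-methylbenzyl would show whether the methyl and fluorine groups can be exchanged on the benzyl amide.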